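Aryl substituent on the saturated ring: working notes

The compounds below may be only part of what the source reports. "The series", "measured", "known", "first", "only" and "open" are said of these compounds alone.

Measured in a functional assay on CHO cells for positive allosteric modulation of metabotropic glutamate receptor 2 (Homo sapiens), with a stated time of 30 min; on this read-out higher numbers stand for larger maximal responses and lower numbers for smaller maximal responses:
compound 1 `CC(C)CCn1ccc(N2CCCCC2)c(C#N)c1=O` gives 185%
compound 2 `N#Cc1c(N2CCC(c3cccc(F)c3)CC2)ccn(CC2CC2)c1=O` gives 268%
compound 3 `N#Cc1c(N2CCC(c3cccc(C(F)(F)F)c3)CC2)ccn(CC2CC2)c1=O` gives 191%

Compound 2 holds the highest of the three numbers in this assay. Its nearest neighbour is compound 3, with the step of a number 77 percentage points lower from compound 2 to compound 3 (beyond the scatter), and compound 1 lies further off still; both gaps are beyond the scatter.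

Compound 4 `N#Cc1c(N2CCC(c3ccc(F)cc3F)CC2)ccn(CC2CC2)c1=O` differs from compound 2 by 2,4-difluorophenyl in place of 3-fluorophenyl on a saturated ring carbon. For the measured compounds named here, the one measured step that bears on this change is a number 77 percentage points lower from compound 2 to compound 3 (beyond the scatter), where the aromatic substituent was altered on the same saturated ring carbon and the maximal response fell sharply. Going by the values given here, the new change is of a different kind, a second fluorine entering and the single fluorine moving, so the drop need not be as large; no pair in the set shows this exact change, and compound 1, which carries no aryl group at all, sits near compound 3.

Taking the one relevant step as a guide, a downward movement smaller than that step is expected, giving compound 4 an estimated 215% in this assay. This means an expected step of a number 53 percentage points lower from compound 2 to compound 4 (beyond the scatter), with the estimate spanning 160% to 275%.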

Compound 4, largest response reached (Emax), in percent of the reference or control that the assay uses: 272%
The estimate for compound 4 lay 57 percentage points below the measured number; the range from low to high includes it.
By their numbers in this assay, from the lowest: compounds 1 and 3 (each within the scatter of the next); then compounds 2 and 4 (each within the scatter of the next).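

In this assay, 2,4-difluorophenyl in place of 3-fluorophenyl on a saturated ring carbon gives a number 4 percentage points higher from compound 2 to compound 4 (within the scatter), so the two maximal responses cannot be told apart. For the compounds shown here, until now the only step at this position was a number 77 percentage points lower from compound 2 to compound 3 (beyond the scatter); read together, the two steps show that altering the aryl group here need not cost maximal response, and that the loss seen so far belongs to the trifluoromethyl change alone, with compound 4 going against any general reading of aryl changes as harmful. No measurement at hand accounts for the difference between these two changes.

Compound 4 differs from compound 2 both in the number of fluorines and in where they stand on the phenyl ring, so the two changes cannot be separated here, and a monofluorophenyl group with the fluorine placed differently would be needed to do so. Also open is how the maximal response behaves with a chloro or methoxy group on this phenyl ring, or with a ring-bound carboxylic acid or amine, since all aryl substituents shown are fluorine-based.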